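The source may hold more compounds than are shown below. What is called first, only, known or untested is meant among the compounds shown, and "the series" means these compounds.

Compound 1 `COc1cc(NC(C)CCCNC(=O)Nc2cccc(Cl)c2)c2ncccc2c1`: 21000 nM
Compound 2 `COc1cc(NC(C)CCCNC(=O)NNC(=O)Nc2ccc(F)cc2)c2ncccc2c1`: >= 250000 nM (a limit)
Compound 3 `COc1cc(NC(C)CCCNC(=O)NNC(=O)Nc2ccc(C(F)(F)F)cc2)c2ncccc2c1`: 19000 nM

In a functional assay on MIA PaCa-2 cells (Homo sapiens) for inhibition, read by MTT assay, with a stated time of 72 h (on this read-out lower numbers stand for stronger inhibition and higher numbers for weaker inhibition), compound 2 stands at >= 250000 nM, which is a limit and not a number. Compound 4 `COc1cc(NC(C)CCCNC(=O)Nc2cccc(O)c2)c2ncccc2c1` carries 3-hydroxyphenyl in place of ((4-fluorophenyl)carbamoyl)amino on an amide-type nitrogen. Among the measured compounds shown here, two measured steps bear on this change. The closer one is an at least 11-fold higher number from compound 1 to compound 2 (1.07 log units; beyond the scatter), a large step in which the same group replaced 3-chlorophenyl at that place. The other, an at least 13-fold lower number from compound 2 to compound 3 (1.11 log units; beyond the scatter), was also large and shows that compound 2 can be improved by a change elsewhere. Compound 4 reverses the first kind of change, so a large move to a lower number is expected. The estimated step is an at least 8.3-fold lower number from compound 2 to compound 4 (0.92 log units; beyond the scatter). For compound 4 the estimated value is 30000 nM, with an expected range of 10000 nM to 90000 nM.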

Compound 4, half-maximal inhibitory concentration: 46000 nM
Estimate against measurement, compound 4: 1.5-fold (0.19 log units) below; the measured number falls inside the stated range.
By their numbers in this assay, from the lowest: compounds 3 and 1 (each within the scatter of the next); then compound 4. At a limit, above all of these: compound 2.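

In this assay, placing 3-hydroxyphenyl on the amide-type nitrogen gives an at least 5.4-fold lower number from compound 2 to compound 4 (0.73 log units; beyond the scatter), but this step is only a bound, since the value of compound 2 is a limit: the limit of >= 250000 nM in this assay, at which 1 of the 4 values shown sits. Hydroxy in place of chloro on an aromatic carbon gives a 2.2-fold higher number from compound 1 to compound 4 (0.34 log units; beyond the scatter), the first step shown that keeps the aryl group directly on that nitrogen and changes only its substituent. This step is modest, while the replacement of 3-chlorophenyl by ((4-fluorophenyl)carbamoyl)amino was large. On these data alone, how an amine or a carboxylic acid would read on that aromatic carbon remains open.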